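The source may hold more compounds than are shown below. What is called first, only, known or untested is meant among the compounds shown, and "the series" means these compounds.

Working notes on the series. In a functional assay on HCT-8 cells (Homo sapiens) for antiproliferative activity, read by MTT assay, with a stated time of 48 h (a higher number here means a weaker inhibitor, a lower number a stronger inhibitor), compound 1 (`COc1ccc(C(=O)c2ccc3c(c2)C=CC(C)(C)O3)c(NC(=O)CBr)c1`) gives 3260 nM and compound 2 (`CNCC(=O)Nc1cc(OC)ccc1C(=O)c1ccc(OC)c2c1C=CC(C)(C)O2`) gives 3460 nM. Compound 3 (`C=C(c1cc(OC)c(OC)c(OC)c1)c1ccc(OC)cc1NC(=O)CO`) stands lowest of the three at 40 nM, beyond the scatter from both of the others.

Compound 4 (`C=C(c1cc(OC)c(OC)c(OC)c1)c1ccc(OC)cc1NC(=O)CN`) departs from compound 3 by a single exchange: amino in place of hydroxy on a saturated chain carbon bound to a carbonyl carbon. This places amino in place of hydroxy on a saturated chain carbon bound to a carbonyl carbon. Within the data shown here, no measured pair isolates this exchange, and compounds 1 and 2 do not share the core of compound 3, so their values offer no direct guide. The expectation therefore rests on compound 3 at 40 nM, with a modest move toward a higher number in this assay, possibly no larger than the scatter. The estimated change is a 1.8-fold higher number from compound 3 to compound 4 (0.24 log units; within the scatter). For compound 4 the expected value is 70 nM, with an estimated range of 20 nM to 300 nM.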

Compound 4, half-maximal inhibitory concentration: 60 nM
Compound 4: middle estimate off by 1.2-fold (0.07 log units), on the high side; the range from low to high includes it.
By their numbers in this assay, from the lowest: compounds 3 and 4 (each within the scatter of the next); then compounds 1 and 2 (each within the scatter of the next).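

Among these compounds, this is the first step that isolates a single place: in this assay, amino in place of hydroxy on a saturated chain carbon bound to a carbonyl carbon gives a 1.5-fold higher number from compound 3 to compound 4 (0.18 log units; within the scatter). At this place the assay therefore does not separate the two groups, and compound 4 remains within the scatter of compound 3. No available evidence explains this result.

Going by these compounds, it remains open whether a larger group at this place, such as dimethylamino or a carboxylic acid, or a longer chain, such as aminoethyl in place of aminomethyl, would also stay within the scatter of compound 3. This single pair also leaves open whether the same exchange would give a similar step on the core of compound 1 or compound 2.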